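Ester tail changes on a Rho kinase inhibitor

The compounds below may be only part of what the source reports. "The series", "measured", "known", "first", "only" and "open" are said of these compounds alone.

Measured so far:
compound 1 `CC(C)OCCOC(=O)c1cccc(-c2cc(C(=O)Nc3ccncc3F)ccc2CN)c1`: 37 nM
compound 2 `NCc1ccc(C(=O)Nc2ccncc2F)cc1-c1cccc(C(=O)OCCO)c1`: 1.4 nM

In an assay on isolated protein for inhibition of Rho-associated protein kinase 2 (Homo sapiens), read by radiometric assay (a lower number here means a stronger inhibitor, a higher number a weaker inhibitor), compound 2 gives the lowest of the two numbers; its nearest neighbour is compound 1, which shows a 26-fold lower number from compound 1 to compound 2 (1.42 log units; beyond the scatter). Compound 3 `NCc1ccc(C(=O)Nc2ccncc2F)cc1-c1cccc(C(=O)OCC2CCCCO2)c1` is the next step: oxan-2-yl in place of hydroxymethyl on a saturated chain carbon bound to an oxygen next to a carbonyl group. Among the compounds with values here, the only step that bears on this change, from compound 1 to compound 2, replaced a bulkier group with a free hydroxyl and gave a large improvement. Compound 3 goes the other way, removing that hydroxyl and adding a ring, so a weaker inhibitor is expected, a 21-fold higher number from compound 2 to compound 3 (1.33 log units; beyond the scatter). Compound 3 is therefore estimated at 30 nM, within 8 nM to 120 nM.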

Compound 3, half-maximal inhibitory concentration: 12 nM
Compound 3: middle estimate off by 2.5-fold (0.40 log units), on the high side; the range from low to high includes it.
By their numbers in this assay, from the lowest: compound 2; then compound 3; then compound 1.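

In this assay, putting oxan-2-yl in place of hydroxymethyl on the saturated chain carbon gives a weaker inhibitor (an 8.6-fold higher number from compound 2 to compound 3 (0.93 log units; beyond the scatter)). Yet oxan-2-yl compares well with isopropoxymethyl at that carbon (a 3.1-fold lower number from compound 1 to compound 3 (0.49 log units; beyond the scatter)), so the two tails without a hydroxyl are not equivalent, and the one with the ring gives the stronger inhibitor. No measured evidence accounts for either step.

Still open, going by these compounds, is how an amine or a carboxylic acid at this carbon would compare with hydroxymethyl. Also open, on these data alone, is whether the ring oxygen matters, which cyclohexyl in place of oxan-2-yl would test.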